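The compounds below may be only part of what the source reports. "The series", "measured", "known", "first", "only" and "open" are said of these compounds alone.

Measured compounds:

- compound 1, `CCN(CC)CCNC(=O)c1ccc(C(CC)(CC)c2ccc(OCCC(O)(CC)CC)c(C)c2)n1CC`: in an assay on cells for agonist activity at vitamin D3 receptor (Homo sapiens), with a stated time of 96 h (a lower number here means that less compound is needed, a higher number that more compound is needed for the effect), compound 1 gives 2.3 nM
- compound 2, `CCn1c(C(=O)N(CCC#N)CCC#N)ccc1C(CC)(CC)c1ccc(OCCC(O)(CC)CC)c(C)c1`: in this assay compound 2 gives only a limit, > 10000 nM
- compound 3, `CCC(C)C(NC(=O)c1ccc(C(CC)(CC)c2ccc(OCCC(O)(CC)CC)c(C)c2)n1CC)C(=O)OC`: in this assay compound 3 gives only a limit, > 10000 nM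

Among the measured compounds shown here, compound 1 holds the only numerical value among the three; the other two sit at the limit of > 10000 nM in this assay, at which 2 of the 3 values shown sit. Compound 4, `CCn1c(C(=O)N(C)CC(=O)O)ccc1C(CC)(CC)c1ccc(OCCC(O)(CC)CC)c(C)c1`, differs from compound 1 at a single site: (carboxymethyl)(methyl)amino in place of (2-(diethylamino)ethyl)amino on a carbonyl carbon.

For the measured compounds named here, two measured steps bear on this change, since both also replace the (2-(diethylamino)ethyl)amino group on the amide of compound 1. The first, an at least 4300-fold higher number from compound 1 to compound 2 (3.63 log units; beyond the scatter), and the second, an at least 4300-fold higher number from compound 1 to compound 3 (3.63 log units; beyond the scatter), each run to the limit. Compound 4 likewise loses the (2-(diethylamino)ethyl)amino group, so a large rise in this assay is expected, of the order of a 3500-fold higher number from compound 1 to compound 4 (3.54 log units; beyond the scatter). Compound 4 is therefore estimated at 8000 nM, with a range from 500 nM to 50000 nM, and the result may well be reported only as a limit.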

Compound 4, half-maximal effective concentration: 89 nM
Estimate against measurement, compound 4: 90-fold (1.95 log units) above, outside the stated range (below it).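

Replacing the (2-(diethylamino)ethyl)amino group on the carbonyl carbon still costs activity in this assay, with a 39-fold higher number from compound 1 to compound 4 (1.59 log units; beyond the scatter), but compound 4 keeps a measurable value. The earlier replacements gave only a limit, which left no graded reading of this position: the limit of > 10000 nM in this assay, at which 2 of the 4 values shown sit. Compound 4 shows that the position tells replacements apart, with an at least 110-fold lower number from compound 3 to compound 4 (2.05 log units; beyond the scatter) and an at least 110-fold lower number from compound 2 to compound 4 (2.05 log units; beyond the scatter), so losing the (2-(diethylamino)ethyl)amino group does not by itself take the value to the limit.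

On these data alone, it remains open how a longer chain carrying the carboxylic acid, or a methyl ester in place of that acid, would read in this assay. The compounds shown also do not separate the contribution of the carboxymethyl part from that of the methyl part of the entering group.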